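The source may hold more compounds than are shown below. What is called first, only, known or untested is meant among the compounds shown, and "the series" means these compounds.

Compound 1 `COc1cc2c(cc1OC)CN(c1ccc(F)cc1)CC2` is the lower of the two compounds measured in a physicochemical assay for lipophilicity, at pH 7.4; a lower number here means a more polar compound, a higher number a more lipophilic compound: compound 1 gives 4.5, while compound 2 `COc1cc2c(cc1OC)CN(c1cc(C(F)(F)F)cc(C(F)(F)F)c1)CC2` gives 5.7, a gap beyond the usual scatter. Compound 3 `COc1cc2c(cc1OC)CN(c1cccnc1)CC2` differs from compound 1 in one place: pyridin-3-yl in place of 4-fluorophenyl on an amine nitrogen in a ring. Within the data shown here, no measured pair shows this change, so the expectation rests on the change alone. A fall in lipophilicity beyond the scatter is expected, the step being estimated as a number 1.40 log units lower from compound 1 to compound 3 (beyond the scatter). Compound 3 is therefore expected to give 3.1, most likely somewhere between 2.5 and 3.7.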

Compound 3, distribution coefficient: 3.7
For compound 3 the middle estimate is 0.60 log units below the measured one; low and high end bracket the measured number.
By their numbers in this assay, from the lowest: compound 3; then compound 1; then compound 2.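

In this assay, putting pyridin-3-yl in place of 4-fluorophenyl on the amine nitrogen in a ring gives a number 0.80 log units lower from compound 1 to compound 3 (beyond the scatter). Among these compounds, this is the first single-place step at this position, and it shows that the number responds to which six-membered aromatic ring sits there, even when only the ring atoms and the fluorine differ. The compounds shown leave open how much of the step belongs to the ring nitrogen and how much to the lost fluorine, a split that plain phenyl at this position could show. Nothing measured here says why the number moves.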